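Changing the Sulfonyl Aryl Group: Compound 2 to Compound 4

A few compounds are considered here, and "the series" means these few. Any claim that something is new, unique, unknown or untested is made for them only; others in the source may bear on it.

Three compounds sharing one core have been measured in a functional assay on PC-3 cells (Homo sapiens) for inhibition; on this read-out lower numbers stand for stronger inhibition and higher numbers for weaker inhibition:

Compound 1, `COc1cc2nc(N3CCN(S(=O)(=O)c4ccc(Cl)s4)CC3)nc(N)c2cc1OC`, gives 25000 nM.
Compound 2, `COc1cc2nc(N3CCN(S(=O)(=O)c4ccccc4[N+](=O)[O-])CC3)nc(N)c2cc1OC`, gives 35000 nM.
Compound 3, `COc1cc2nc(N3CCN(S(=O)(=O)c4ccc(C(=O)O)cc4)CC3)nc(N)c2cc1OC`, gives 53000 nM.

All three differ only in the aryl group attached to the sulfonyl sulfur. Compound 2 holds the second highest of the three numbers, and the steps of a 1.4-fold higher number from compound 1 to compound 2 (0.15 log units; within the scatter) and a 1.5-fold higher number from compound 2 to compound 3 (0.18 log units; within the scatter) both lie within the scatter. Compound 4, `COc1cc2nc(N3CCN(S(=O)(=O)c4ccc5ccccc5c4)CC3)nc(N)c2cc1OC`, is the next change from compound 2: naphthalen-2-yl in place of 2-nitrophenyl on a sulfonyl sulfur. Within the data shown here, no measured step introduces a naphthalenyl group, so the only guidance comes from the aryl swaps already seen: a 1.4-fold higher number from compound 1 to compound 2 (0.15 log units; within the scatter), a 1.5-fold higher number from compound 2 to compound 3 (0.18 log units; within the scatter) and a 2.1-fold higher number from compound 1 to compound 3 (0.33 log units; beyond the scatter), of which only the last reaches beyond the scatter, and then only modestly. On this basis the change is expected to give a step of a 1.2-fold lower number from compound 2 to compound 4 (0.07 log units; within the scatter) in this assay, no larger than the scatter in either direction. Compound 4 is therefore estimated at 30000 nM, with a range from 12000 nM to 75000 nM.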

Compound 4, half-maximal inhibitory concentration: 15000 nM
For compound 4 the middle estimate is 2.0-fold (0.30 log units) above the measured one; the measured number falls inside the stated range.
By their numbers in this assay, from the lowest: compounds 4, 1, 2 and 3 (each within the scatter of the next, the first and the last beyond it).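

In this assay, among these compounds, naphthalen-2-yl is the first group on the sulfonyl sulfur to stand apart from 2-nitrophenyl by more than the scatter, with a 2.3-fold lower number from compound 2 to compound 4 (0.37 log units; beyond the scatter) as the step, and the change from 4-carboxyphenyl gives a 3.5-fold lower number from compound 3 to compound 4 (0.55 log units; beyond the scatter) as the largest step. Even so, a 1.7-fold lower number from compound 1 to compound 4 (0.22 log units; within the scatter) stays within the scatter, so naphthalen-2-yl cannot be told apart from the 5-chlorothiophen-2-yl group and the aryl position shows no single best group. Nothing measured here accounts for these differences.

From the compounds shown here alone, it remains open how a plain phenyl, or a phenyl carrying an amine, would compare on the same sulfonyl sulfur. These compounds also leave open what happens when the methoxy groups of the shared core are replaced.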